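The source may report more compounds than this note shows. Statements on the series, on what has been measured and on what is new or still open speak of the compounds shown alone.

Compound 3 `CC(C)(Oc1ccc(NCc2cccc(Oc3ccccc3)c2)cc1)C(=O)O` stands lowest of the three measured compounds: in a functional assay on CHO cells for agonist activity at Free fatty acid receptor 1 (Homo sapiens), read by a luciferase reporter (a higher number here means a larger maximal response, a lower number a smaller maximal response), compound 3 reaches 14%, whereas compound 1 `Cc1nc(-c2ccc(C(F)(F)F)cc2)sc1CNc1ccc(CCC(=O)O)cc1` gives 108% and compound 2 `Cc1nc(-c2ccc(C(F)(F)F)cc2)sc1CNc1ccc(/C=C/C(=O)O)cc1` gives 95%. Compound 4 `CN(C)C(=O)CCc1ccc(NCc2cccc(Oc3ccccc3)c2)cc1` differs from compound 3 in one place, (2-(dimethylcarbamoyl)ethyl in place of 1-carboxy-1-methylethoxy on an aromatic carbon). Within the data shown here, the only measured step, a number 13 percentage points lower from compound 1 to compound 2 (beyond the scatter), concerns a different change on a different core, so no step directly covers the exchange of 1-carboxy-1-methylethoxy for 2-(dimethylcarbamoyl)ethyl. Since compound 3 is already near the bottom of the scale, a small downward step or none beyond the scatter is expected, namely a number 6 percentage points lower from compound 3 to compound 4 (within the scatter). Compound 4 is therefore estimated at 8%, with a likely range from 0% to 25%.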

Compound 4, largest response reached (reported as percent of maximum), in percent of the reference or control that the assay uses: 50%
For compound 4 the middle estimate is 42 percentage points below the measured one; the measured number lies above the stated range.
By their numbers in this assay, from the lowest: compound 3; then compound 4; then compound 2; then compound 1.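

In this assay, exchanging 1-carboxy-1-methylethoxy for 2-(dimethylcarbamoyl)ethyl at this position gives a number 36 percentage points higher from compound 3 to compound 4 (beyond the scatter), so on this core a group without a carboxylic acid can give the larger response. Both groups count the same number of heavy atoms, so that count does not separate them, yet the exchange alters the acid, the ether oxygen and the branching together. Nothing shown gives a reason for the rise.

Which of these alterations matters remains open. A 2-(dimethylamino)ethyl group or a 2-carbamoylethyl group at this position could help separate them.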